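The compounds below may be only part of what the source reports. "The series", "measured", "known", "first", "only" and "open" are said of these compounds alone.

Compound 1 `CC(C)[C@H](NC(=O)CN(c1nc(Cl)nc2[nH]cnc12)C1CC1)C(=O)OCc1ccccc1`: 27.3%
Compound 2 `CC[C@H](C)[C@H](NC(=O)CN(c1nc(Cl)nc2[nH]cnc12)C1CC1)C(=O)O`: 21.4%
Compound 3 `CC[C@H](C)[C@H](NC(=O)CN(c1nc(Cl)nc2[nH]cnc12)C1CC1)C(=O)OCc1ccccc1`: 22%

These three compounds share one core and were tested in a functional assay on the whole organism (Tail, strain ICR) with Mus musculus as the target, in the tail flick test, with a stated time of 120 min, at a dose of 25 umol/kg by the oral route; on this read-out lower numbers stand for a weaker effect and higher numbers for a stronger effect at the one dose given. Compound 2 gives the smallest number of the three, yet the step of a number 0.6 percentage points higher from compound 2 to compound 3 (within the scatter) and its gap to compound 1 both lie within the scatter, so the three cannot really be told apart. Compound 4 `C[C@H](NC(=O)CN(c1nc(Cl)nc2[nH]cnc12)C1CC1)C(=O)O` has not been measured; it differs from compound 2 by methyl in place of sec-butyl on a saturated chain carbon bound to an amide-type nitrogen and a carbonyl carbon. For the measured compounds named here, the one measured step that also touches this side chain, a number 5.3 percentage points lower from compound 1 to compound 3 (within the scatter), stayed within the scatter, and the unrelated step a number 0.6 percentage points higher from compound 2 to compound 3 (within the scatter) did too. No movement beyond the scatter is therefore expected in this assay. Compound 4 is estimated at 21%, with a range from 10% to 32%. That corresponds to an expected step of a number 0.4 percentage points lower from compound 2 to compound 4 (within the scatter).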

Compound 4, a percentage reported as activity, at one dose (the size of the read-out at that dose, not a potency): 28.4%
For compound 4 the middle estimate is 7.4 percentage points below the measured one; the range from low to high includes it.
By their numbers in this assay, from the lowest: compounds 2, 3, 1 and 4 (each within the scatter of the next).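

In this assay, for the compounds shown here, the earlier side-chain step changed only one methyl group, and it did so among benzyl esters. With the free acid, going from sec-butyl to methyl on this saturated chain carbon gives a number 7 percentage points higher from compound 2 to compound 4 (within the scatter), so even this larger change does not separate the two compounds. Nothing available explains this result. Still open, going by these compounds, is whether a phenyl ring or an amine on this carbon would move the read-out beyond the scatter. Also open, on these data alone, is how the methyl compound behaves as a benzyl ester.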